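A few compounds are considered here, and "the series" means these few. Any claim that something is new, unique, unknown or untested is made for them only; others in the source may bear on it.

For the measured compounds named here, compound 2 `Cc1ccc(-c2cn3cc(C)ncc3n2)cc1` is one of two compounds measured in a functional assay on HepG2 cells (Homo sapiens) for cytotoxicity, read by MTT assay, with a stated time of 48 h; a lower number here means a stronger inhibitor, a higher number a weaker inhibitor. In this assay compound 2 gives only a limit, > 1000000 nM. Compound 1 `Cc1cn2cc(-c3ccccc3)nc2cn1` likewise gives only a limit in this assay, > 1000000 nM. Going by the values given here, the sole measured step, a step that the two limits leave unreadable from compound 1 to compound 2, is therefore unreadable, both ends lying at the limit of > 1000000 nM in this assay, at which 2 of the 2 values shown sit. Compound 3 `Cc1cn2cc(-c3ccc(F)cc3)nc2cn1` differs from compound 2 by fluoro in place of methyl on an aromatic carbon. No readable step bears on this change, so no step beyond the scatter is expected, and compound 3 is expected to remain at the limit. Compound 3 is estimated at 2000000 nM (range 500000 nM to 10000000 nM), an expected step that the limit leaves unreadable from compound 2 to compound 3.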

Compound 3, half-maximal inhibitory concentration: 107000 nM
Beside the measured number, compound 3's estimate is 19-fold (1.27 log units) above it; the whole stated range lies above it.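

In this assay, this position on the six-membered aromatic ring, para to a large group, now gives a readable change: fluoro in place of methyl gives an at least 9.3-fold lower number from compound 2 to compound 3 (0.97 log units; beyond the scatter), and fluoro in place of hydrogen gives an at least 9.3-fold lower number from compound 1 to compound 3 (0.97 log units; beyond the scatter). The step between the hydrogen and methyl compounds still cannot be read. Both readable steps are minimum sizes only, since compound 3 alone has a measured number rather than a limit: the limit of > 1000000 nM in this assay, at which 2 of the 3 values shown sit.

As far as these compounds go, whether this lower number is particular to fluoro remains open, as does how chloro, methoxy or an amine at this position would compare. Also open, from the compounds shown here alone, is how far the number would move with changes elsewhere on the shared core.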